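A few compounds are considered here, and "the series" means these few. Any claim that something is new, unique, unknown or untested is made for them only; others in the source may bear on it.

Compound 1 `NC(=O)/C=C1\CCc2c(F)cc(F)cc21`: 100%
Compound 2 `Cc1cccc2c1/C(=C/C(=O)NC1CC1)CC2`: 17%
Compound 3 `O=C(/C=C1\CCc2c(F)cc(F)cc21)NC1CC1`: 100%

In a functional assay on the whole organism with Mus musculus as the target, at a dose of 100 mg/kg by the intraperitoneal route (on this read-out higher numbers stand for more inhibition at the one dose given (going by the name of the read-out) and lower numbers for less inhibition), compound 3 gives 100% and compound 1 gives 100%. The two share a core and differ only by hydrogen in place of cyclopropyl on an amide-type nitrogen, a change that produced no change at the digits printed from compound 3 to compound 1 (within the scatter). Compound 2, built on a different core, gives 17% in this assay, and how the core of compound 2 differs from that of compound 3 is not broken down here.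

Compound 4 `Cc1cccc2c1/C(=C/C(N)=O)CC2` has not yet been measured in this assay. It stands to compound 2 as compound 1 stands to compound 3: the difference is hydrogen in place of cyclopropyl on an amide-type nitrogen, the same change, made at the same kind of place, as the one already seen. Because that earlier change gave no change at the digits printed from compound 3 to compound 1 (within the scatter), the same change is expected to leave the reading of compound 2 roughly where it is, so the step of a number 8 percentage points higher from compound 2 to compound 4 (within the scatter) is estimated to be small. For the measured compounds named here, compound 4 is therefore expected to give about 25% in this assay, most likely between 5% and 60%, though the only precedent rests on two compounds whose readings sit at the same high level, which limits what it can show.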

Compound 4, a percentage reported as inhibition, in the whole organism at one dose (the size of the read-out at that dose, not a potency): 100%
Estimate against measurement, compound 4: 75 percentage points below, outside the stated range (above it).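

In this assay, putting hydrogen in place of cyclopropyl on the amide-type nitrogen gives a number 83 percentage points higher from compound 2 to compound 4 (beyond the scatter). Set beside the earlier pair, the same change does not carry over from one core to the other: the same change on two cores in this assay, no change at the digits printed (within the scatter) from compound 3 to compound 1 and a number 83 percentage points higher (beyond the scatter) from compound 2 to compound 4, 83 percentage points apart, beyond the scatter of two such steps. This shows that, in these two pairs, the result of the change cannot be read from one core to the other, but it does not show which difference between the cores is responsible, and with compound 3 already at 100% at the one dose given, the first pair could not reveal a rise of the kind seen on the other core.

The compounds shown leave open whether a methyl group or a longer chain such as n-propyl on that nitrogen would read like hydrogen or like cyclopropyl on either core. They also leave open how a carboxylic acid in place of the amide would read, and whether the gap between the two steps would hold at lower doses.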